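A few compounds are considered here, and "the series" means these few. Any claim that something is new, unique, unknown or untested is made for them only; others in the source may bear on it.

The measured compounds:
Compound 1, `COc1cc2c(Nc3cccc(C#N)c3)ncnc2cc1OCCCN1CCCC1`, in a functional assay on SH-SY5Y cells (Homo sapiens) for antiproliferative activity, read by MTT assay, with a stated time of 72 h (a higher number here means a weaker inhibitor, a lower number a stronger inhibitor), gives 10600 nM.
Compound 2, `COc1cc2c(Nc3cccc(C#N)c3)ncnc2cc1OCCCN1CCCCC1`, gives 11200 nM.
Compound 3, `COc1cc2c(Nc3cccc(C#N)c3)ncnc2cc1OCCCN1CCN(C)CC1`, gives 6890 nM.

Among the compounds with values here, compound 2 carries the highest of the three numbers, but no compound is set apart from it: a 1.1-fold higher number from compound 1 to compound 2 (0.02 log units; within the scatter), and a 1.6-fold lower number from compound 2 to compound 3 (0.21 log units; within the scatter). The third pair agrees, a 1.5-fold lower number from compound 1 to compound 3 (0.19 log units; within the scatter). All three measured steps change only the saturated amine at the end of the chain, pyrrolidin-1-yl, piperidin-1-yl or 4-methylpiperazin-1-yl, and none of them moves the numbers beyond the scatter.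

Compound 4, `COc1cc2c(Nc3ccccc3C#N)ncnc2cc1OCCCN1CCCCC1`, has not been measured in this assay. It differs from compound 2 in one place: 2-cyanophenyl in place of 3-cyanophenyl on a nitrogen on an aromatic ring. Within the data shown here, none of the measured steps touches the cyanophenyl group on the ring nitrogen, so no measured step bears on this change, and the data give no direction for it. Compound 4 is therefore expected to stay close to compound 2, with the expected step being a 1.0-fold lower number from compound 2 to compound 4 (0.01 log units; within the scatter). Compound 4 is estimated at 11000 nM, within a range from 3500 nM to 35000 nM.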

Compound 4, half-maximal inhibitory concentration: 13400 nM
Compound 4: middle estimate off by 1.2-fold (0.09 log units), on the low side; low and high end bracket the measured number.
By their numbers in this assay, from the lowest: compounds 3, 1, 2 and 4 (each within the scatter of the next).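

In this assay, a change away from the chain-end amine, 2-cyanophenyl in place of 3-cyanophenyl on a nitrogen on an aromatic ring, gives a 1.2-fold higher number from compound 2 to compound 4 (0.08 log units; within the scatter) and so stays inside the scatter. The cyanophenyl group is thus a second place in the molecule where a single change leaves the number unmoved, and with piperidin-1-yl at the chain end these two nitrile placements cannot be told apart. Nothing measured here offers an explanation for this result.

From the compounds shown here alone, whether the same swap would hold with pyrrolidin-1-yl or 4-methylpiperazin-1-yl at the chain end remains open. Also open, going by these compounds, is what a phenyl with no nitrile, or with a chlorine in place of the nitrile, would give on that nitrogen.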